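The source may hold more compounds than are shown below. What is called first, only, known or untested is meant among the compounds shown, and "the series" means these compounds.

In a functional assay on U-937 cells (Homo sapiens) for inhibition, read by scintillation counting, with a stated time of 15 min (on this read-out lower numbers stand for stronger inhibition and higher numbers for weaker inhibition), compound 1 `O=C(NC1CCCCCC1)c1c(-c2ccccc2)c(Br)cn(Cc2ccc(F)cc2)c1=O` gives > 10000 nM, which is a limit of the assay and not a number. Compound 2 `Cc1c(-c2ccccc2)cn(Cc2ccc(F)cc2)c(=O)c1C(=O)NC1CCCCCC1` has no number of its own, and its result reads "not determined" (no result reported). Compound 3 `O=C(NC1CCCCCC1)c1c(-c2ccccc2)c(-c2ccccc2)cn(Cc2ccc(F)cc2)c1=O` has not yet been measured. The change is phenyl in place of methyl on an aromatic carbon. Going by the values given here, no measured step shows what this change does, so in this assay no clear step towards stronger inhibition is expected, resting on compound 1 and (the limit of > 10000 nM in this assay, at which 1 of the 2 values shown sits). Compound 3 is estimated at about 10000 nM, with an expected range from 1500 nM to 30000 nM.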

Compound 3, half-maximal inhibitory concentration: > 10000 nM
Compound 3 was reported as a limit (the forecaster's own chance of this, stated with the estimate: 60%); the middle value lies on the limit itself.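

No step can be read between compound 1 and compound 3, since each is reported only as a limit of the assay: the limit of > 10000 nM in this assay, at which 2 of the 3 values shown sit.
From the compounds shown here alone, how strongly either compound inhibits, and whether phenyl and bromo differ on the shared core, stays open.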